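One More Fluoro Group and Lipophilicity

The source may report more compounds than this note shows. Statements on the series, on what has been measured and on what is new or still open speak of the compounds shown alone.

Compound 1 `Cc1cc(COc2cccc(F)c2F)nc(-c2ccccn2)n1` and compound 2 `Cc1cc(COc2ccc(F)c(F)c2)nc(-c2ccccn2)n1` are built from the same atoms joined differently; the difference between the two cores is not broken down here. In a physicochemical assay for lipophilicity, at pH 7.4 (on this read-out higher numbers stand for higher lipophilicity and lower numbers for lower lipophilicity), compound 1 gives 3.2, and compound 2 gives 3.2, so the two stand level. Compound 3 `Cc1cc(COc2c(F)ccc(F)c2F)nc(-c2ccccn2)n1` differs from compound 1 by fluoro in place of hydrogen on an aromatic carbon, and in this assay compound 3 gives 3.1; the measured step is a number 0.10 log units lower from compound 1 to compound 3 (within the scatter). Compound 4 `Cc1cc(COc2cc(F)c(F)cc2F)nc(-c2ccccn2)n1` has not yet been measured and differs from compound 2 by the same change, (fluoro in place of hydrogen on an aromatic carbon), with the surroundings of its place described in identical words. The expected step is a number 0.10 log units lower from compound 2 to compound 4 (within the scatter), resting on compound 1 and compound 3 because a number 0.10 log units lower from compound 1 to compound 3 (within the scatter). Compound 4 is expected to give 3.1, most likely between 2.8 and 3.4.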

Compound 4, distribution coefficient: 3.2
The estimate for compound 4 lay 0.10 log units below the measured number, and the stated range covers the measured number.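

In this assay the new step reads no change at the digits printed from compound 2 to compound 4 (within the scatter) and the earlier step reads a number 0.10 log units lower from compound 1 to compound 3 (within the scatter) on the other core, so on both cores fluoro in place of hydrogen on an aromatic carbon gives a step within the scatter. The change therefore carries between these two cores without a step that can be told from the scatter, but two steps show nothing about other cores or other places on the ring. Nothing shown here explains the result.

The compounds shown carry only fluoro groups on this ring, so it stays open how an amine or a trifluoromethyl group would read in this assay on either core. As far as these compounds go, whether such a group would give a step beyond the scatter also stays open.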